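Notes on the amine change from compound 3 to compound 4

The compounds below may be only part of what the source reports. "The series", "measured", "known", "first", "only" and "open" are said of these compounds alone.

Values in a functional assay on NCI-H460 cells (Homo sapiens) for inhibition, read by sulforhodamine B assay, with a stated time of 72 h (a higher number here means a weaker inhibitor, a lower number a stronger inhibitor), for the series:
- compound 1 `CCNC(=O)c1nnn(-c2cc(C(C)C)c(O)cc2O)c1-c1ccc(CN2CCCC(O)C2)cc1` gives 62 nM
- compound 2 `CCNC(=O)c1nnn(-c2cc(C(C)C)c(O)cc2O)c1-c1ccc(CN2CCC[C@@H](O)C2)cc1` gives 52 nM
- compound 3 `CCNC(=O)c1nnn(-c2cc(C(C)C)c(O)cc2O)c1-c1ccc(CN2CCC(N(C)C)CC2)cc1` gives 120 nM

Compound 3 lies within the scatter of compound 1 and stands apart only from compound 2. The numbers show a 1.9-fold higher number from compound 1 to compound 3 (0.29 log units; within the scatter) and also a 2.3-fold higher number from compound 2 to compound 3 (0.36 log units; beyond the scatter) which is a modest step. The remaining step, a 1.2-fold lower number from compound 1 to compound 2 (0.08 log units; within the scatter) comes down to the fact that one of compounds 1 and 2 is drawn with a defined configuration and the other without, at the place where they differ and does not bear on the next change.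

Compound 4 `CCNC(=O)c1nnn(-c2cc(C(C)C)c(O)cc2O)c1-c1ccc(CNC2CCN(C)CC2)cc1` differs from compound 3 by (1-methylpiperidin-4-yl)amino in place of 4-(dimethylamino)piperidin-1-yl on a saturated chain carbon bound to an aromatic carbon and the change stays on a saturated chain carbon bound to an aromatic carbon. Going by the values given here, the two replacements at this place are the only guide, and neither is large. Given those steps from compound 1 and compound 2, no step beyond the scatter is expected in this assay in either direction. The expected step is a 1.1-fold lower number from compound 3 to compound 4 (0.04 log units; within the scatter) and this estimate means no real change. In this assay the estimate for compound 4 is 110 nM with 45 nM to 270 nM as the expected span.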

Compound 4, half-maximal inhibitory concentration: > 1000 nM
Compound 4 was reported as a limit (the forecaster's own chance of this, stated with the estimate: 2%); middle value at least 9.0-fold (0.95 log units) from the limit.
By their numbers in this assay, from the lowest: compounds 2, 1 and 3 (each within the scatter of the next, the first and the last beyond it). At a limit, above all of these: compound 4.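

In this assay compound 4 stands only as a limit: the limit of > 1000 nM in this assay, at which 1 of the 4 values shown sits. The largest earlier step at this place, on a saturated chain carbon bound to an aromatic carbon, was a 2.3-fold higher number from compound 2 to compound 3 (0.36 log units; beyond the scatter), whereas this change gives an at least 8.3-fold higher number from compound 3 to compound 4 (0.92 log units; beyond the scatter), along with an at least 19-fold higher number from compound 2 to compound 4 (1.28 log units; beyond the scatter) and an at least 16-fold higher number from compound 1 to compound 4 (1.20 log units; beyond the scatter). The place therefore accepts 3-hydroxypiperidin-1-yl and 4-(dimethylamino)piperidin-1-yl in this assay but separates sharply between 4-(dimethylamino)piperidin-1-yl and (1-methylpiperidin-4-yl)amino, even though the two groups differ little in size and the entering group adds a hydrogen-bond donor.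

The compounds shown cannot separate that added donor from the rearranged amine as the source of the step. A methyl(1-methylpiperidin-4-yl)amino group at this place, which keeps the rearranged amine without the amine hydrogen, would be the direct test.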